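A few compounds are considered here, and "the series" means these few. Any claim that something is new, unique, unknown or untested is made for them only; others in the source may bear on it.

Compound 1 `CC1=C(/C=C/C(=O)/C=C/c2cccc(C(F)(F)F)c2)C(C)(C)CCC1O` gives 1400 nM in a functional assay on LNCaP C4-2B cells (Homo sapiens) for cytotoxicity, read by MTT assay, with a stated time of 72 h; on this read-out higher numbers stand for weaker inhibition and lower numbers for stronger inhibition.
Compound 2 `CC1=C(/C=C/C(=O)/C=C/c2cc(C(F)(F)F)ccc2C(F)(F)F)C(C)(C)CCC1O` gives "not determined" (no result reported) in this assay.
Compound 3 `CC1=C(/C=C/C(=O)/C=C/c2cccc(F)c2)C(C)(C)CCC1O` gives "not determined" (no result reported) in this assay.

In this assay compound 1 gives 1400 nM. Among the measured compounds shown here, this is the only number in the set: compound 2 was included, but in this assay compound 2 gives "not determined" (no result reported); likewise compound 3 gives "not determined" (no result reported), so compound 1 stands alone and cannot be ranked against anything.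

Compound 4 `CC1=C(/C=C/C(=O)/C=C/c2ccc(F)c(C(F)(F)F)c2)C(C)(C)CCC1O` differs from compound 1 by fluoro in place of hydrogen on an aromatic carbon. For the measured compounds named here, no step between two measured compounds is available to guide the expectation, so the estimate rests on the single value of compound 1 alone. Nothing in the data points to a large shift in either direction; the step is expected to be a 1.1-fold lower number from compound 1 to compound 4 (0.03 log units; within the scatter), a change within the usual scatter. Compound 4 is therefore estimated to give 1300 nM, with a range from 500 nM to 3500 nM.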

Compound 4, half-maximal inhibitory concentration: 7300 nM
For compound 4 the middle estimate is 5.6-fold (0.75 log units) below the measured one, outside the stated range (above it).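

Putting fluoro in place of hydrogen at this position, ortho to a trifluoromethyl group, gives a 5.2-fold higher number from compound 1 to compound 4 (0.72 log units; beyond the scatter) in this assay, which means weaker inhibition. A single added fluorine atom is therefore enough to change the result at this place on the ring, something compound 1 alone could not show. No measurement shown here explains this shift.

Going by these compounds, it remains open whether a chlorine atom, a methoxy group or an amine at the same position would also weaken inhibition. Whether fluoro has the same effect without the neighbouring trifluoromethyl group is also unknown.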